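This account rests on a few compounds, and the source may have more. Where it says the series, first, only, none or still open, it means among the compounds named here.

Compound 1 `CCCCCCOc1ccc2nncn2n1` gives 32.9 mg/kg in a functional assay on the whole organism with Mus musculus as the target; on this read-out higher numbers stand for an effect only at larger amounts of compound and lower numbers for an effect already at smaller amounts.
Compound 2 `Cc1ccc(Oc2ccc3nncn3n2)cc1` gives only a limit, > 100 mg/kg, in this assay.
Compound 3 `COc1ccccc1Oc1ccc2nncn2n1` gives only a limit, > 100 mg/kg, in this assay.

Compound 2 therefore stands at the upper edge of what this assay reports, together with one other value, as the limit of > 100 mg/kg in this assay, at which 2 of the 3 values shown sit, shows; for compound 2 no number is known, only that limit. Compound 4 `Fc1ccc(Oc2ccc3nncn3n2)cc1` differs from compound 2 by fluoro in place of methyl on an aromatic carbon. Among the compounds with values here, no measured pair with this exchange is available, so the account can only weigh the small size of the change. Compound 4 is expected to give 150 mg/kg, within 60 mg/kg to 400 mg/kg. The estimated step that the limit leaves unreadable from compound 2 to compound 4 is thus expected to stay within the usual scatter, most likely ending again at a limit rather than a number.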

Compound 4, dose for half-maximal effect: 38 mg/kg
Estimate against measurement, compound 4: 3.9-fold (0.60 log units) above; measured number outside the range, below it.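

Fluoro in place of methyl, on an aromatic carbon para to a large group, gives an at least 2.6-fold lower number from compound 2 to compound 4 (0.42 log units; beyond the scatter) in this assay. This position therefore matters to the read-out: one exchange of a single heavy atom here is enough to give a number where compound 2 gave none. Compound 2 is known only by a limit, so the step has a minimum size and no exact one: the limit of > 100 mg/kg in this assay, at which 2 of the 4 values shown sit.

The compounds shown leave open how chloro, trifluoromethyl or an amine would read at this same place. They also leave open whether fluoro elsewhere on this ring would give a similar result.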